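This account rests on a few compounds, and the source may have more. Where it says the series, first, only, none or still open, it means among the compounds named here.

In an assay on isolated protein for inhibition of cathepsin S (Homo sapiens), read by fluorescence (a higher number here means a weaker inhibitor, a lower number a stronger inhibitor), compound 1 `CCc1nccn1CCCOc1ccc(-c2cccc(C#N)n2)cc1C(F)(F)F` gives 31 nM. Two further compounds share a chain of three saturated carbons running from an oxygen on an aromatic ring, but carry a different end group and a different arrangement in the ring that bears the nitrile. Compound 2 `N#Cc1cc(-c2ccc(OCCCO)c(C(F)(F)F)c2)ccn1` is reported as "not active" (no number reported) in this assay, without a number. Compound 3 `CN1CCN(CCCOc2ccc(-c3ccnc(C#N)c3)cc2C(F)(F)F)CC1` is likewise reported as "not active" (no number reported) in this assay, again with no number given. So compound 3 stands among the compounds for which inhibition was not seen at the concentrations tested, and no measured value fixes where it lies.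

Compound 4 `CCc1nccn1CCCOc1ccc(-c2ccnc(C#N)c2)cc1C(F)(F)F` differs from compound 3 in one place: 2-ethyl-1H-imidazol-1-yl in place of 4-methylpiperazin-1-yl on a saturated chain carbon, three bonds along the chain from an oxygen on an aromatic ring. The group that enters is the same one compound 1 carries at the end of its chain, while the rest of compound 4 matches compound 3 rather than compound 1. Among the measured compounds shown here, no measured pair isolates this change in this assay. Since compound 3 gives "not active" (no number reported) and compound 2 gives "not active" (no number reported), the step is expected to move, if at all, toward a measurable but modest inhibition; it may also remain without a number. Compound 4 is estimated at 3000 nM, with a range from 300 nM to 30000 nM.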

Compound 4, half-maximal inhibitory concentration: "not active" (no number reported)
For compound 4 the study gives words and no number; there is nothing to compare the estimate with.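

In this assay compound 3 and compound 4 are both reported as not active without a number, so no step can be read between them. Nothing shown offers an explanation for this result. The compounds shown leave open whether replacing 4-methylpiperazin-1-yl with 2-ethyl-1H-imidazol-1-yl changes inhibition at all.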